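A few compounds are considered here, and "the series" means these few. Any claim that something is new, unique, unknown or untested is made for them only; others in the source may bear on it.

Compound 1 `C=CCc1cc(OC)c(OC(C)C(OCCCCCCCC)c2ccc(O)c(OC)c2)c(OC)c1` stands at the low end of three numbers in an assay on HEK293 cells for agonist activity at transient receptor potential cation channel subfamily M member 8 (Homo sapiens), read by fluorescence and calcium flux, with a stated time of 5 min (on this read-out lower numbers stand for an effect already at smaller amounts and higher numbers for an effect only at larger amounts of compound), where compound 1 gives 86 nM. Compound 2 `C=CCc1cc(OC)c(O[C@@H](C)[C@@H](OCC)c2ccc(O)c(OC)c2)c(OC)c1` gives 87 nM in this assay, and compound 3 `C=CCc1cc(OC)c(O[C@@H](C)[C@H](OCC)c2ccc(O)c(OC)c2)c(OC)c1` gives 1130 nM; the step of a 13-fold higher number from compound 2 to compound 3 (1.11 log units; beyond the scatter) rests on (the fact that compounds 2 and 3 differ only in the configuration as drawn). Compound 4 `C=CCc1cc(OC)c(OC(C)C(O[C@H]2C[C@@H](C)CC[C@@H]2C(C)C)c2ccc(O)c(OC)c2)c(OC)c1` is compound 1 with a group of 10 heavy atoms (10 carbon; one six-membered non-aromatic ring of carbon only) in place of a group of 8 heavy atoms (8 carbon; no ring), on an oxygen on a saturated carbon. Going by the values given here, no measured step exchanges one group for another on that oxygen, so the measured steps bear on it only indirectly, and the size of the expected change cannot be read from them. Compound 4 is therefore expected to remain near compound 1, with an estimated step of a 1.7-fold higher number from compound 1 to compound 4 (0.24 log units; within the scatter). The estimate for compound 4 in this assay is 150 nM, ranging from 40 nM to 600 nM.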

Compound 4, half-maximal effective concentration: 11 nM
Beside the measured number, compound 4's estimate is 14-fold (1.13 log units) above it, outside the stated range (below it).
By their numbers in this assay, from the lowest: compound 4; then compounds 1 and 2 (each within the scatter of the next); then compound 3.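

On this oxygen, exchanging octyl for the ring-bearing group gives a 7.8-fold lower number from compound 1 to compound 4 (0.89 log units; beyond the scatter) in this assay, so the group held there moves the number, as configuration alone had done earlier. Nothing given here accounts for this step.

From the compounds shown here alone, whether the ring or the carbon count carries the step stays open, and a decyl chain on the same oxygen would separate the two. Also open, going by these compounds, is whether the three defined stereocentres of the entering group matter, and whether configuration at the chain carbons counts here as it did in a 13-fold higher number from compound 2 to compound 3 (1.11 log units; beyond the scatter).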